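Smaller side chain on the shared core: compound 4

This account rests on a few compounds, and the source may have more. Where it says the series, first, only, none or still open, it means among the compounds named here.

Compound 1 `COc1ccc(OC)c(CCC(=O)N2CCN(c3ccc(C(F)(F)F)cc3[C@@H](N)CC(C)C)CC2)c1`: 2500 nM
Compound 2 `CCC(C)CN[C@H](c1cc(C(F)(F)F)ccc1N1CCN(C(=O)CCc2ccc(Cl)cc2Cl)CC1)C(C)CC`: 2800 nM
Compound 3 `CCC(C)[C@H](NCc1ccccc1F)c1cc(C(F)(F)F)ccc1N1CCN(C(=O)CCc2ccc(Cl)cc2Cl)CC1`: > 10000 nM

In an assay on HEK293 cells for displacement of a labelled ligand from Melanocortin receptor 4 (Homo sapiens) (on this read-out higher numbers stand for weaker inhibition and lower numbers for stronger inhibition), compound 2 gives 2800 nM, the higher of the two numbers shown, and compound 1 sits within the scatter of it. For compound 3 the result is only a limit of the assay (the limit of > 10000 nM in this assay, at which 1 of the 3 values shown sits). Within the data shown here, that step, an at least 3.5-fold higher number from compound 2 to compound 3 (0.55 log units; beyond the scatter), is the one measured change bearing on this position. Compound 4 `CN[C@@H](CC(C)C)c1cc(C(F)(F)F)ccc1N1CCN(C(=O)CCc2ccc(Cl)cc2Cl)CC1` differs from compound 2 by 3-methyl-1-(methylamino)butyl in place of 2-methyl-1-((2-methylbutyl)amino)butyl on an aromatic carbon. The change removes bulk rather than adding an aryl group, so the worsening seen toward compound 3 is not expected to repeat. The estimate for compound 4 is 1500 nM, between 400 nM and 6000 nM, meaning an expected step of a 1.9-fold lower number from compound 2 to compound 4 (0.27 log units; within the scatter).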

Compound 4, inhibition constant: 1900 nM
Estimate against measurement, compound 4: 1.3-fold (0.10 log units) below; the measured number falls inside the stated range.
By their numbers in this assay, from the lowest: compounds 4, 1 and 2 (each within the scatter of the next). At a limit, above all of these: compound 3.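

With 3-methyl-1-(methylamino)butyl in place of 2-methyl-1-((2-methylbutyl)amino)butyl, this assay shows a 1.5-fold lower number from compound 2 to compound 4 (0.17 log units; within the scatter) and thus no measurable loss. This position, previously probed by a single change that ended at a limit of the assay, therefore accepts a much smaller side chain on the aromatic carbon without a shift beyond the scatter. Nothing among the data shown accounts for this result.

Going by these compounds, whether the amine itself is needed remains open. A hydroxyl group in its place, or a cyclopropylmethyl group on its nitrogen, would address that question.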